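Amino-to-methyl swap on the fused core: expected acid dissociation

This account rests on a few compounds, and the source may have more. Where it says the series, first, only, none or still open, it means among the compounds named here.

Compound 1, `Cc1nc2c(CCc3ccccc3)cccn2c1N`, is the reference point of this small set. In a physicochemical assay for acid dissociation, compound 1 gives 7.3, the highest of the three numbers in hand. Compound 2, `Cc1nc2c(/C=C/c3ccccc3)cccn2c1C`, gives 7.2 in this assay, a number that sits within the scatter of compound 1. Compound 3, `Cc1c(C(F)(F)F)nc2c(OCc3ccccc3)cccn12`, gives 2, a number far below both and well beyond the scatter. No two of the three measured compounds differ in one place only, so no single-point step can be read off among them.

The next compound, compound 4, `Cc1nc2c(CCc3ccccc3)cccn2c1C`, differs from compound 1 in exactly one place: methyl in place of amino on an aromatic carbon. The question is what size of step this change produces in this assay. For the measured compounds named here, the measured set gives no direct step of this kind. Compound 2, which also carries a methyl rather than an amino on its core, gives 7.2, close to the value of compound 1, which suggests that the step from compound 1 to compound 4 is expected to be small, with no direction beyond the scatter; the expected step is no change at the digits printed from compound 1 to compound 4 (within the scatter). Compound 4 is therefore estimated at 7.3, in a range from 6.8 to 7.8.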

Compound 4, acid dissociation constant: 7.5
Compound 4: middle estimate off by 0.20 log units, on the low side; the range from low to high includes it.
By their numbers in this assay, from the lowest: compound 3; then compounds 2, 1 and 4 (each within the scatter of the next).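

On an aromatic carbon of the five-membered aromatic ring, next to the ring nitrogen, methyl in place of amino gives in this assay a number 0.20 log units higher from compound 1 to compound 4 (within the scatter). For the compounds shown here, this is the first direct reading at this position, as the earlier compounds contained no pair differing in one place only. At this position, on this core, exchanging amino, with its one hydrogen-bond donor and one hydrogen-bond acceptor, for methyl, with neither, produces no step beyond the scatter, and the data on hand offer no account of that result.

Still open, from the compounds shown here alone, is how other groups on the same aromatic carbon would read in this assay, for example a carboxylic acid, a nitrile or a longer chain such as propyl, as this single step covers only amino and methyl. Also open is whether the same exchange would give a similar step with the other substituents of compound 2 or compound 3, as neither compound has a partner among those shown that differs from it in this one place.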